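Ethylurea in Place of the Chloroalkyl Amide

This account rests on a few compounds, and the source may have more. Where it says the series, first, only, none or still open, it means among the compounds named here.

Compound 1 `CC(C)c1ccccc1OS(=O)(=O)c1ccc(NC(=O)CCl)cc1` and compound 2 `CC(C)c1ccccc1OS(=O)(=O)c1ccc(NC(=O)CCCCl)cc1` share a sulfonate core. In a functional assay on HT-1080 cells (Homo sapiens) for antiproliferative activity, read by sulforhodamine B assay, with a stated time of 48 h (on this read-out higher numbers stand for weaker inhibition and lower numbers for stronger inhibition), compound 1 gives 1000 nM, and compound 2 gives 3800 nM. Going by the values given here, the step of a 3.8-fold higher number from compound 1 to compound 2 (0.58 log units; beyond the scatter) is the only measured step. Compound 2 therefore holds the higher of the two numbers, with compound 1 the nearer and only neighbour.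

Compound 3 `CCNC(=O)Nc1ccc(S(=O)(=O)Oc2ccccc2C(C)C)cc1` carries the change (ethylamino in place of 3-chloropropyl on a carbonyl carbon). Among the compounds with values here, the one measured step, lengthening the chloroalkyl chain from compound 1 to compound 2, does not cover the removal of the chlorine or the arrival of a hydrogen-bond donor, so no measured step bears directly on this change. Compound 3 is therefore expected, with wide uncertainty, to give 8000 nM, between 2000 nM and 30000 nM. Within the data shown here, the step of a 2.1-fold higher number from compound 2 to compound 3 (0.32 log units; beyond the scatter) is estimated to be a modest rise, beyond the scatter, but this rests on no measured precedent.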

Compound 3, half-maximal inhibitory concentration: 250 nM
Estimate against measurement, compound 3: 32-fold (1.51 log units) above, and the stated range ends above it.
By their numbers in this assay, from the lowest: compound 3; then compound 1; then compound 2.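

In this assay, ethylamino in place of 3-chloropropyl on a carbonyl carbon gives a 15-fold lower number from compound 2 to compound 3 (1.18 log units; beyond the scatter) and, in place of chloromethyl, gives a 4.0-fold lower number from compound 1 to compound 3 (0.60 log units; beyond the scatter) on the same cells. A chlorine-bearing chain is therefore not required at this position for antiproliferative activity: compound 3, which has no chlorine, is the most potent of the three, with both steps beyond the scatter. Nothing measured here accounts for this gain. The compounds shown leave open whether the gain follows the loss of the chlorine or the arrival of the nitrogen, which a plain propyl chain or a 2-chloroethylamino group on the same carbonyl carbon would separate. Going by these compounds, how far a longer chain on that nitrogen, or a ring there, would be tolerated also remains open.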